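The source may hold more compounds than are shown below. What is called first, only, known or untested is meant among the compounds shown, and "the series" means these compounds.

Measured compounds:
- compound 1 `O=c1cc(-c2ccccc2)oc2cc(OCc3ccccc3)c(OCCCCN3CCCCC3)c(O)c12`: 1900 nM
- compound 2 `O=c1cc(-c2ccccc2)oc2cc(O)c(OCCCCN3CCCCC3)c(O)c12`: 75000 nM
- compound 3 `COc1cc2oc(-c3ccccc3)cc(=O)c2c(O)c1OCCCCN1CCCCC1`: 34000 nM

All three were tested in a functional assay on A549 cells (Homo sapiens) for antiproliferative activity, read by MTT assay, with a stated time of 48 h; on this read-out higher numbers stand for weaker inhibition and lower numbers for stronger inhibition. On these numbers compound 1 stands lowest, that is, it is the strongest inhibitor of the three. Replacing the benzyl on one ring oxygen by hydrogen gave a 39-fold higher number from compound 1 to compound 2 (1.60 log units; beyond the scatter), and replacing the phenyl on the chain carbon next to that oxygen by hydrogen gave an 18-fold higher number from compound 1 to compound 3 (1.25 log units; beyond the scatter); both changes weakened inhibition markedly. Between the two weaker compounds, a methyl in place of hydrogen on that ring oxygen gave a 2.2-fold lower number from compound 2 to compound 3 (0.34 log units; beyond the scatter).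

Compound 4 `CN1CCN(CCCOc2c(OCc3ccccc3)cc3oc(-c4ccccc4)cc(=O)c3c2O)CC1` keeps the benzyl group of compound 1 unchanged and differs at the far end of the side chain: 4-methylpiperazin-1-yl in place of (piperidin-1-yl)methyl on a saturated chain carbon, three bonds along the chain from an oxygen on an aromatic ring. Among the measured compounds shown here, none of the measured steps touches this part of the molecule; all three concern the benzyl-bearing oxygen. There is therefore no direct guide, and the step is expected to be small, likely within the scatter, perhaps with a modest weakening.

Compound 4 is estimated at 2800 nM, with a range from 900 nM to 9000 nM, corresponding to an expected step of a 1.5-fold higher number from compound 1 to compound 4 (0.17 log units; within the scatter).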

Compound 4, half-maximal inhibitory concentration: 1300 nM
Beside the measured number, compound 4's estimate is 2.2-fold (0.33 log units) above it, and the stated range covers the measured number.
By their numbers in this assay, from the lowest: compounds 4 and 1 (each within the scatter of the next); then compound 3; then compound 2.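

In this assay, the exchange of 4-(piperidin-1-yl)butyl for 3-(4-methylpiperazin-1-yl)propyl gives a 1.5-fold lower number from compound 1 to compound 4 (0.16 log units; within the scatter). Among the compounds shown here, this is the first information on the far end of the side chain, and it shows that this end can take a different ring and a different chain length together without a change that stands out from the scatter. The contrast with the benzyl-bearing oxygen is clear, since replacing the benzyl there by hydrogen gave a 39-fold higher number from compound 1 to compound 2 (1.60 log units; beyond the scatter), whereas compound 4 keeps that benzyl and cannot be told apart from compound 1; nothing available here explains this tolerance.

On these data alone, because ring and chain length changed in a single step, their separate contributions stay unknown, and they could even be pulling in opposite directions. A 4-(4-methylpiperazin-1-yl)butyl or a 3-(piperidin-1-yl)propyl side chain would separate the two, while a morpholine ring or a simple dimethylamino group would show how far the amine at the chain end can depart from these two rings.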